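Swapping the hydroxyphenyl pattern on a pyridine triaryl

A few compounds are considered here, and "the series" means these few. Any claim that something is new, unique, unknown or untested is made for them only; others in the source may bear on it.

Compound 1 `Oc1ccc(-c2cc(-c3cccc(O)c3)nc(-c3cccc(O)c3)c2)cc1`: 1760 nM
Compound 2 `Oc1cccc(-c2cc(-c3ccccc3O)cc(-c3ccccc3O)n2)c1`: 3980 nM
Compound 3 `Oc1ccc(-c2cc(-c3ccc(O)cc3)nc(-c3cccc(O)c3)c2)cc1`: 5800 nM

In a functional assay on DU-145 cells (Homo sapiens) for cytotoxicity, read by CCK-8 assay, with a stated time of 4 days (a higher number here means a weaker inhibitor, a lower number a stronger inhibitor), compound 3 gives the highest number of the three; compound 2 sits within the scatter of it, while compound 1 lies clearly lower. Going by the values given here, the one measured step that touches compound 3 is a 3.3-fold higher number from compound 1 to compound 3 (0.52 log units; beyond the scatter). Compound 4 `Oc1ccc(-c2cc(-c3cccc(O)c3)nc(-c3ccccc3O)c2)cc1` differs from compound 3 by 2-hydroxyphenyl in place of 4-hydroxyphenyl on an aromatic carbon. Among the compounds with values here, no measured pair isolates a 2-hydroxyphenyl exchange; compound 2, which carries two such groups, merely sits between compound 1 and compound 3. Since moving away from 4-hydroxyphenyl lowered the number from compound 1 to compound 3 in reverse, a modest drop is expected, giving a 1.7-fold lower number from compound 3 to compound 4 (0.22 log units; within the scatter). Compound 4 is therefore estimated at 3500 nM, between 1500 nM and 8000 nM.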

Compound 4, half-maximal inhibitory concentration: 3420 nM
Estimate against measurement, compound 4: 1.0-fold (0.01 log units) above; the range from low to high includes it.
By their numbers in this assay, from the lowest: compounds 1, 4, 2 and 3 (each within the scatter of the next, the first and the last beyond it).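

At the place next to the ring nitrogen, 2-hydroxyphenyl cannot be told apart from the other hydroxyphenyl groups in this assay: all three new steps stay within the scatter (a 1.7-fold lower number from compound 3 to compound 4 (0.23 log units; within the scatter); a 1.2-fold lower number from compound 2 to compound 4 (0.07 log units; within the scatter); a 1.9-fold higher number from compound 1 to compound 4 (0.29 log units; within the scatter)). Only the exchange of 4-hydroxyphenyl for 3-hydroxyphenyl stands beyond it (a 3.3-fold higher number from compound 1 to compound 3 (0.52 log units; beyond the scatter)). Nothing here accounts for these steps.

As far as these compounds go, what stays open is whether the hydroxyl is needed at all at this place, and whether a plain phenyl, an aminophenyl or a carboxyphenyl there would shift the number beyond the scatter.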